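Iodine for Methyl on the Fused Core

The source may hold more compounds than are shown below. What is called first, only, known or untested is meant among the compounds shown, and "the series" means these compounds.

Of the compounds shown here, three sharing one core have been measured in a functional assay on CHO cells for antagonist activity at Orexin/Hypocretin receptor type 1 (Homo sapiens), read by FLIPR and calcium flux; on this read-out higher numbers stand for weaker inhibition and lower numbers for stronger inhibition. Compound 1 `CCc1nc(SC)c2n1CCN([C@@H](C(=O)NC)c1ccccc1)[C@H]2CCc1ccc(C(F)(F)F)cc1` gives 85 nM. Compound 3 `CNC(=O)[C@@H](c1ccccc1)N1CCn2c(C)nc(Cl)c2[C@@H]1CCc1ccc(C(F)(F)F)cc1` gives 90 nM. Compound 2 `CCc1nc(C)c2n1CCN([C@@H](C(=O)NC)c1ccccc1)C2CCc1ccc(C(F)(F)F)cc1` gives 10000 nM, the highest number of the three; its nearest neighbour is compound 3 and its furthest is compound 1, and both gaps lie beyond the usual scatter, so compound 2 is the weakest inhibitor among them.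

The account now follows a single change on that core. Compound 4 `CCc1nc(I)c2n1CCN([C@@H](C(=O)NC)c1ccccc1)C2CCc1ccc(C(F)(F)F)cc1` differs from compound 2 by iodo in place of methyl on an aromatic carbon. Going by the values given here, no step between two measured compounds maps this exact change, so what follows is an expectation rather than a reading of a measured step.

Compound 2 sits far above the other two in this assay, and the other two, which carry different groups at the same kind of position, both sit low. Because compound 2 gives 10000 nM while compound 3 gives 90 nM, a large downward step in this assay is expected from compound 2 to compound 4, of about a 33-fold lower number from compound 2 to compound 4 (1.52 log units; beyond the scatter). Compound 4 is thus expected to give about 300 nM in this assay, with a range from 60 nM to 1500 nM.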

Compound 4, half-maximal inhibitory concentration: 717 nM
Compound 4: middle estimate off by 2.4-fold (0.38 log units), on the low side; the range from low to high includes it.
By their numbers in this assay, from the lowest: compounds 1 and 3 (each within the scatter of the next); then compound 4; then compound 2.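

In this assay, going by these compounds alone, iodo in place of methyl on this aromatic carbon gives a 14-fold lower number from compound 2 to compound 4 (1.14 log units; beyond the scatter), the first direct reading of this position between two compounds that differ nowhere else. The change leaves the count at one heavy atom and adds no hydrogen-bond donors, hydrogen-bond acceptors or net charge, yet the step lies well beyond the scatter, so the read-out is sensitive to the identity of the group on this carbon even when these counts stay the same. No measurement is available that accounts for the size of this step.

The compounds shown leave open how other groups on this same carbon, such as bromo, a nitrile or an amine, would read with the ethyl group and the rest of the core held fixed. They also leave open whether iodo in place of methyl would give a step of similar size if the ethyl group were replaced by a methyl or a longer chain.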